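Butyl to propyl on an amide-type nitrogen

This account rests on a few compounds, and the source may have more. Where it says the series, first, only, none or still open, it means among the compounds named here.

In a functional assay on HeLa cells (Homo sapiens) for cytotoxicity, read by MTT assay, with a stated time of 72 h (a higher number here means a weaker inhibitor, a lower number a stronger inhibitor), compound 1 (`CC(C)(C)NC(=S)N/N=C1\CC(c2ccc(O)cc2)Oc2cc(O)ccc21`) gives 50000 nM as its value. Compound 2 (`CCCCNC(=S)N/N=C1\CC(c2ccc(O)cc2)Oc2cc(O)ccc21`) gives > 100000 nM as its result, and that is a limit of the assay and not a number. Compound 3 (`CCCNC(=S)N/N=C1\CC(c2ccc(O)cc2)Oc2cc(O)ccc21`) carries hydrogen in place of methyl on a saturated chain carbon, three bonds along the chain from an amide-type nitrogen, which turns butyl into propyl. Going by the values given here, the only measured step on this chain is an at least 2.0-fold higher number from compound 1 to compound 2 (0.30 log units; that floor lies within the scatter) and it gives a floor, not a size, for a different change. Resting on an at least 2.0-fold higher number from compound 1 to compound 2 (0.30 log units; that floor lies within the scatter) as the sole guide, no step beyond the scatter and no direction is expected in this assay for this change. The expected size is an at least 1.2-fold lower number from compound 2 to compound 3 (0.09 log units; that floor lies within the scatter) and the reading may again be only a limit. Compound 3 is estimated at 80000 nM with an expected range from 35000 nM to 150000 nM as the working figures.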

Compound 3, half-maximal inhibitory concentration: 40200 nM
Compound 3: the middle estimate sits 2.0-fold (0.30 log units) above what was measured; low and high end bracket the measured number.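

In this assay, going by these compounds alone, going from butyl to propyl on the amide-type nitrogen gives the first step that lies beyond the scatter: an at least 2.4-fold lower number from compound 2 to compound 3 (0.39 log units; beyond the scatter). Compound 2 stands at a limit of the assay and not a number, so this step gives only a floor for the change: the limit of > 100000 nM in this assay, at which 1 of the 3 values shown sits. Propyl and tert-butyl on this nitrogen cannot be told apart in this assay, with a 1.2-fold lower number from compound 1 to compound 3 (0.09 log units; within the scatter), so among these three compounds butyl alone stands apart.

Three compounds cannot show whether butyl is an isolated case or part of a trend with chain length; ethyl, methyl or a longer chain such as pentyl on the same nitrogen would bear on this. On these data alone, the full size of the step from butyl also remains open, as does the effect of an amine or a carboxylic acid at the end of the chain.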